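The source may hold more compounds than are shown below. What is called first, only, known or untested is meant among the compounds shown, and "the series" means these compounds.

Measured so far in a functional assay on PC-3 cells (Homo sapiens), read by fluorescence and BrdU incorporation, with a stated time of 48 h, tested at 10 uM; a higher number here means a weaker effect of the compound at the concentration tested, a lower number a stronger effect:
- compound 1 `COc1cccc(/C=C/C(=O)c2c(OC)cc(OC)cc2OC)c1` gives 23%
- compound 2 `COc1cc(OC)c(C(=O)/C=C/c2ccccc2)c(OC)c1` gives 24%
- compound 3 `COc1cc(OC)c(C(=O)/C=C/c2ccc(F)cc2)c(OC)c1` gives 27%

Compound 1 carries the lowest of the three numbers, but its nearest neighbour is compound 2 with a number 1 percentage points higher from compound 1 to compound 2 (within the scatter), and the furthest is compound 3 with a number 4 percentage points higher from compound 1 to compound 3 (within the scatter). The remaining pair, a number 3 percentage points higher from compound 2 to compound 3 (within the scatter), is of the same kind. All three values therefore sit together within the scatter, and no order among them can be read from these numbers.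

Compound 4 `COc1cccc(/C=C/C(=O)c2c(O)cc(OC)cc2OC)c1` differs from compound 1 by hydrogen in place of methyl on an oxygen on an aromatic ring. Within the data shown here, none of the measured steps makes this change: the closest is the step from compound 1 to compound 2, hydrogen in place of methoxy on an aromatic carbon, which left the read-out within the scatter, as did the changes on the double-bonded chain carbon. Nothing measured here separates methyl from hydrogen on an aromatic oxygen, so the expectation rests on the general flatness of the series. The expected step for compound 4 is a number 2 percentage points higher from compound 1 to compound 4 (within the scatter), that is none beyond the scatter. Compound 4 is therefore estimated at 25%, with a range of 10% to 45%.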

Compound 4, a percentage reported as activity, at one concentration (the size of the read-out at that concentration, not a potency): 39%
Beside the measured number, compound 4's estimate is 14 percentage points below it, and the stated range covers the measured number.
By their numbers in this assay, from the lowest: compounds 1, 2 and 3 (each within the scatter of the next); then compound 4.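

In this assay, among these compounds, methoxy to hydroxy on the aromatic ring gives a number 16 percentage points higher from compound 1 to compound 4 (beyond the scatter), the only step so far that lies beyond the scatter and the first sign that the series is not flat to every change. Hydrogen in place of methoxy on an aromatic carbon and the changes on the double-bonded chain carbon left the read-out within the scatter, whereas this small change, with a single carbon leaving and hydrogen entering on the oxygen, weakens the effect at the concentration tested, so the methyl on this oxygen matters to the read-out in a way those other places did not show. The step is modest and rests on one pair of compounds, and nothing at hand accounts for it.

Going by these compounds, it remains open whether a longer chain on this oxygen, such as ethoxy, would hold the read-out of compound 1 or move it as hydroxy does. Also open, on these data alone, is whether an amine in this place, or the same methoxy to hydroxy change on the cores of compound 2 and compound 3, would give a step of similar size.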